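The source may report more compounds than this note shows. Statements on the series, on what has been measured and on what is new or still open speak of the compounds shown alone.

Compound 1 `Clc1ccc(C(c2ccccc2)N2CCN(c3ncnc4c3cnn4-c3ccccc3)CC2)cc1` gives > 25000 nM.
Compound 2 `Cc1ccsc1C(c1ccccc1)N1CCN(c2ncnc3c2cnn3-c2ccccc2)CC1` gives > 25000 nM.
Compound 3 `Cc1ccsc1C(c1ccccc1Br)N1CCN(c2ncnc3c2cnn3-c2ccccc2)CC1` gives > 25000 nM.

In a functional assay on cells (Rhabdomyosarcoma cell, Homo sapiens) for cytotoxicity (a higher number here means a weaker inhibitor, a lower number a stronger inhibitor), compound 1 reaches only > 25000 nM, which is a limit of the assay and not a number. Compound 2 likewise stops at a limit, > 25000 nM. Compound 3 also stops at a limit, > 25000 nM. Compound 1 therefore stands at the edge of what this assay can read, and the same holds for the other two compounds (the limit of > 25000 nM in this assay, at which 3 of the 3 values shown sit). The two steps among the measured compounds, a step that the two limits leave unreadable from compound 1 to compound 2 and a step that the two limits leave unreadable from compound 2 to compound 3, are both left unreadable by these limits; the first of them changes the same position that is changed on the way to compound 4, yet its size cannot be told.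

Compound 4 `c1ccc(C(c2nccs2)N2CCN(c3ncnc4c3cnn4-c3ccccc3)CC2)cc1` differs from compound 1 as follows: 1,3-thiazol-2-yl in place of 4-chlorophenyl on a saturated chain carbon bound to an amine nitrogen in a ring and an aromatic carbon. With every measured step unreadable, the step that the limit leaves unreadable from compound 1 to compound 4 is expected to be no readable step at all, and compound 4 is expected to give 40000 nM, within 15000 nM to 150000 nM, most likely reported again only as a limit.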

Compound 4, half-maximal inhibitory concentration: > 25000 nM
Compound 4 was reported as a limit (the forecaster's own chance of this, stated with the estimate: 85%); the middle value does not contradict the limit.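

The steps from compound 1 and from compound 2 to compound 4 cannot be read in this assay, as compound 4 also stops at a limit: the limit of > 25000 nM in this assay, at which 4 of the 4 values shown sit.

The compounds shown leave open whether any of these groups on the saturated chain carbon changes cytotoxicity at all, and by how much.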